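Replacing a carbamoylphenyl with a trifluoromethylphenyl on the piperazine

This account rests on a few compounds, and the source may have more. Where it says the series, first, only, none or still open, it means among the compounds named here.

Compound 1 `Cc1nc(-c2ccccc2)c(C(=O)N2CCN(c3cccc(C(N)=O)c3)CC2)o1` is one of three analogues sharing a core built around an oxazole carbonyl linked to a cyclic diamine. In a functional assay on HL-60 cells (Homo sapiens) for inhibition, read by MTT assay, with a stated time of 72 h (on this read-out lower numbers stand for stronger inhibition and higher numbers for weaker inhibition), compound 1 gives 71 nM, the lower of the two numbers reported. Compound 3 `CCc1nc(-c2ccccc2F)c(C(=O)N2CCN(c3cccc(Cl)c3)CC2)o1` gives 139 nM in this assay, a result that lies within the scatter of compound 1, so the two cannot be ordered. Compound 2 `COc1cccc(N2CCN(C(=O)c3oc(C)nc3-c3cccc(F)c3)CC2)c1` is reported in this assay as "not active" (no number reported), with no number attached.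

Compound 4 `Cc1nc(-c2ccccc2)c(C(=O)N2CCN(c3ccccc3C(F)(F)F)CC2)o1` has not yet been measured. It differs from compound 1 in one place: 2-(trifluoromethyl)phenyl in place of 3-carbamoylphenyl on an amine nitrogen in a ring. For the measured compounds named here, no step between measured compounds isolates such a change, so the expectation rests on the spread of the three results. Since compound 2 gives "not active" (no number reported) once the amine-nitrogen aryl group is altered, a weakening beyond the scatter is expected for compound 4, estimated as a 4.9-fold higher number from compound 1 to compound 4 (0.69 log units; beyond the scatter). Compound 4 is therefore expected to give about 350 nM in this assay, with a range from 90 nM to 2500 nM.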

Compound 4, half-maximal inhibitory concentration: 120 nM
Compound 4: the middle estimate sits 2.9-fold (0.46 log units) above what was measured; the range from low to high includes it.
By their numbers in this assay, from the lowest: compounds 1, 4 and 3 (each within the scatter of the next).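

On the amine nitrogen in the ring, 2-(trifluoromethyl)phenyl in place of 3-carbamoylphenyl gives a 1.7-fold higher number from compound 1 to compound 4 (0.23 log units; within the scatter) in this assay and so leaves the two compounds unordered. For the compounds shown here, the change removes the hydrogen-bond donor and acceptor counted for 3-carbamoylphenyl, yet compound 4 still has a number within the scatter of compound 1, something the earlier compounds, which differ from compound 1 in more than one place, could not show. No measurement given here accounts for this outcome.

Going by these compounds, the group and its place on the phenyl ring changed together, so their separate contributions remain open. On these data alone, it is also open whether a carboxylic acid or a nitrile on that phenyl ring would keep a number in this range, and the "not active" entry for compound 2 cannot be read against compound 4.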